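Cyclopentyl for Isobutyl: Cytotoxicity Expected to Stay Out of Reach

The compounds below may be only part of what the source reports. "The series", "measured", "known", "first", "only" and "open" are said of these compounds alone.

Of the compounds shown here, two sharing one core have been tested in a toxicity assay on Vero cells (Chlorocebus sabaeus) for cytotoxicity, read by MTT assay, with a stated time of 72 h; a higher number here means a weaker inhibitor, a lower number a stronger inhibitor. Compound 1 `O=C(c1cccc2ccccc12)n1c(C2CCC2)nc2ccccc21` gives in this assay only a limit of the assay, > 10000 nM. Compound 2 `COc1ccc(C(=O)n2c(CC(C)C)nc3ccccc32)cc1` likewise reaches only a limit, giving > 10000 nM in this assay. Compound 2 therefore stands exactly where both measured values sit: the limit of > 10000 nM in this assay, at which 2 of the 2 values shown sit. Going by the values given here, two limits allow no step between measured compounds to be drawn, and no measured difference tells how a change of the side group moves this read-out.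

Compound 3 `COc1ccc(C(=O)n2c(C3CCCC3)nc3ccccc32)cc1` differs from compound 2 in one place: cyclopentyl in place of isobutyl on an aromatic carbon. Nothing measured here points to a shift beyond the usual scatter, so the step from compound 2 to compound 3 is expected to be a step that the limit leaves unreadable from compound 2 to compound 3. Compound 3 is therefore expected to give about 20000 nM, within 10000 nM to 50000 nM, most likely again reported as a limit rather than a number.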

Compound 3, half-maximal inhibitory concentration: > 10000 nM
Compound 3 was reported as a limit; the forecaster's own chance of this, stated with the estimate: 80%; the middle value lies beyond the limit too.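

Compound 3 gives > 10000 nM in this assay, which is a limit of the assay and not a number. Going by these compounds alone, compound 2 also sits at a limit, so no step between compound 2 and compound 3 can be read. Left open is how cyclopentyl and isobutyl truly compare, with every compound shown in one place: the limit of > 10000 nM in this assay, at which 3 of the 3 values shown sit.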